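A few compounds are considered here, and "the series" means these few. Any claim that something is new, unique, unknown or untested is made for them only; others in the source may bear on it.

Measured compounds:
compound 1, `CCN(CC)CN1C(=O)/C(=N/NC(N)=S)c2cc(Cl)ccc21`: 44000 nM
compound 2, `CCN(CC)CN1C(=O)/C(=N/NC(=S)Nc2ccc(OC)cc2)c2ccccc21`: 4400 nM
compound 3, `CCN(CC)CN1C(=O)/C(=N/NC(=S)Nc2ccc(C)cc2)c2ccccc21`: 12000 nM

In a functional assay on HeLa cells (Homo sapiens) for inhibition, read by cell counting, with a stated time of 96 h (on this read-out higher numbers stand for weaker inhibition and lower numbers for stronger inhibition), compound 1 stands highest of the three numbers, with compound 3 nearest and compound 2 furthest from it. Compound 4, `CCN(CC)CN1C(=O)/C(=N/NC(=S)Nc2ccc(Cl)cc2)c2cc(Cl)ccc21`, differs from compound 1 by 4-chlorophenyl in place of hydrogen on an amide-type nitrogen. For the measured compounds named here, no measured step isolates this change: compound 2 and compound 3 also differ from compound 1 in the core, so their values show only that both aryl-bearing compounds give lower numbers than compound 1. Going by the values given here, the single measured step, a 2.7-fold higher number from compound 2 to compound 3 (0.44 log units; beyond the scatter), concerns a substituent on that aryl ring and is modest. For compound 4 a lower number is therefore expected, by a 5.5-fold lower number from compound 1 to compound 4 (0.74 log units; beyond the scatter). The estimate for compound 4 in this assay is 8000 nM, expected between 2500 nM and 25000 nM.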

Compound 4, half-maximal inhibitory concentration: > 125000 nM
Compound 4: no number, only a limit; the forecaster's own chance of this, stated with the estimate: 5%; at least 15-fold (1.19 log units) between middle value and limit.
By their numbers in this assay, from the lowest: compound 2; then compound 3; then compound 1. At a limit, above all of these: compound 4.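

In this assay, compound 4 gives no number, only a limit of the assay: the limit of > 125000 nM in this assay, at which 1 of the 4 values shown sits. Putting 4-chlorophenyl in place of hydrogen on the amide-type nitrogen gives an at least 2.8-fold higher number from compound 1 to compound 4 (0.45 log units; beyond the scatter), the only step shown that isolates this nitrogen. On the core of compound 1, then, this aryl group does not lower the number, and the size of the step is known only as a lower bound.

Going by these compounds, what a benzyl group or a cyclohexyl ring on this nitrogen would give on that core stays open. So does whether the step carries over to the core of compound 2.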